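Methoxy Added to the Anilino Ring of Compound 3

The source may report more compounds than this note shows. Statements on the series, on what has been measured and on what is new or still open speak of the compounds shown alone.

Three compounds have been measured in an assay on CHO cells for displacement of a labelled ligand from adenosine receptor A1 (Homo sapiens), read by scintillation counting, with a stated time of 120 min, tested at 1 uM; on this read-out higher numbers stand for more inhibition at the one concentration tested (going by the name of the read-out) and lower numbers for less inhibition:

compound 1 `Cc1nc2sc(-c3ccc(C(=O)O)cc3)nc2c(=O)[nH]1`, 1%
compound 2 `Cc1nc2sc(-n3ccnc3)nc2c(=O)[nH]1`, 1%
compound 3 `Cc1nc2sc(Nc3ccccc3)nc2c(=O)[nH]1`, 24%

Compound 3 stands highest of these three numbers; compound 1 and compound 2 both lie beyond the usual scatter below it, so compound 3 gives the highest inhibition in this assay of the measured set. Compound 4 `COc1ccc(Nc2nc3c(=O)[nH]c(C)nc3s2)cc1` differs from compound 3 by methoxy in place of hydrogen on an aromatic carbon. Going by the values given here, no measured pair shows this change, so the size of its effect in this assay is unknown; the expectation is a step in neither direction beyond the scatter. Compound 4 is therefore expected to give about 25%, in the range 5% to 50%. The estimated step of a number 1 percentage points higher from compound 3 to compound 4 (within the scatter) is expected to stay within the scatter.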

Compound 4, a percentage reported as inhibition, at one concentration (the size of the read-out at that concentration, not a potency): 1%
Compound 4: the middle estimate sits 24 percentage points above what was measured, and the stated range ends above it.
By their numbers in this assay, from the lowest: compounds 1, 2 and 4 (each within the scatter of the next); then compound 3.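

In this assay, methoxy in place of hydrogen para to a large group gives a number 23 percentage points lower from compound 3 to compound 4 (beyond the scatter) and so shows that this place on the anilino ring does not accept every change. Adding just 2 heavy atoms here is enough to bring compound 4 level with compounds 1 and 2, the other low compounds in the set. No available evidence bears on the cause of this step. On these data alone, it remains open whether a single fluorine atom or a hydroxyl group at this place would keep the inhibition. Methoxy elsewhere on the ring is also an open case.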